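A few compounds are considered here, and "the series" means these few. Any claim that something is new, unique, unknown or untested is made for them only; others in the source may bear on it.

Compound 2 (`CC(C)NC[C@@H]1C[C@H](c2ccc3c(N)ncnn23)[C@@H](O)[C@H]1O`) stands highest of the two compounds measured in an ADME assay on the whole organism (Mus musculus, strain BALB/c) for pharmacokinetics, read by LC-MS, with a stated time of 600 min, at a dose of 20 mg/kg by the oral route (a lower number here means less compound in the circulation, a higher number more compound in the circulation at the dose given), with 830 ng.h/mL, while compound 1 (`CN(CCCNC(=O)Nc1ccc(C(C)(C)C)cc1)C[C@H]1C[C@@H](c2ccc3c(N)ncnn23)[C@H](O)[C@@H]1O`) gives 8.07 ng.h/mL as its nearest neighbour, a gap beyond the scatter. Compound 3 (`CC(C)NC[C@H]1C[C@@H](c2ccc3c(N)ncnn23)[C@H](O)[C@@H]1O`) has the same atoms and bonds as compound 2 and differs only in configuration (the two compounds have the same atoms and bonds and differ only in configuration as drawn: 4 of 4 stereo elements differ (all stereocentres are inverted: mirror images); a stereocentre at a saturated ring carbon is drawn S in compound 2 and R in compound 3; a stereocentre at a saturated ring carbon is drawn R in compound 2 and S in compound 3; a stereocentre at a saturated ring carbon is drawn R in compound 2 and S in compound 3; a stereocentre at a saturated ring carbon is drawn S in compound 2 and R in compound 3), the two being mirror images. Within the data shown here, no measured pair shows what such an inversion does, so no step beyond the scatter is expected, with a slight lean towards a lower number. The estimated change is a 1.4-fold lower number from compound 2 to compound 3 (0.14 log units; within the scatter) and remains within the scatter. For compound 3 the expected value is 600 ng.h/mL with an estimated range from 150 ng.h/mL to 2000 ng.h/mL in this measurement.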

Compound 3, area under the concentration-time curve: 1200 ng.h/mL
Beside the measured number, compound 3's estimate is 2.0-fold (0.30 log units) below it, and the stated range covers the measured number.
By their numbers in this assay, from the lowest: compound 1; then compounds 2 and 3 (each within the scatter of the next).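

In this assay, among these compounds, the first pair that differs in configuration alone gives a 1.4-fold higher number from compound 2 to compound 3 (0.16 log units; within the scatter). With this isopropylamine side chain, inverting all four stereocentres therefore leaves no readable difference in this measurement. The comparison isolates configuration, with no group entering or leaving: the fact that compounds 2 and 3 differ only in the configuration as drawn

As far as these compounds go, whether inverting a single stereocentre, rather than all four, would read the same stays open. Also open, from the compounds shown here alone, is what a cyclopropyl group or a carboxylic acid in place of the isopropyl group would do in this assay.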